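The compounds below may be only part of what the source reports. "The series", "measured", "known", "first", "only" and "open" are said of these compounds alone.

Two compounds of the series have been run in a functional assay on the whole organism (strain Sprague-Dawley) for inhibition, with Rattus norvegicus as the target; on this read-out lower numbers stand for an effect already at smaller amounts and higher numbers for an effect only at larger amounts of compound. Compound 1 `COc1cccc2cc(-c3nn[nH]n3)cnc12` gives 2.5 mg/kg in this assay. For compound 2 `O=c1c(-c2nn[nH]n2)c[nH]c2c(Br)cccc12` this assay reports only a limit, > 5 mg/kg, so no number is known for it; its entry stands at the limit of > 5 mg/kg in this assay, at which 1 of the 2 values shown sits. Among the measured compounds shown here, with one result a number and the other a limit, no step between measured compounds can be stated. Compound 3 `CS(=O)(=O)c1cccc2c(=O)c(-c3nn[nH]n3)c[nH]c12` differs from compound 2 by methylsulfonyl in place of bromo on an aromatic carbon. Nothing measured in the series shows how methylsulfonyl in place of bromo on an aromatic carbon moves this read-out, and compound 2 offers only a limit as the starting point. The step expected in this assay is a number no higher from compound 2 to compound 3 (the limit leaves the size open), stated with wide uncertainty. Compound 3 is therefore estimated at 5 mg/kg in this assay, within 1.5 mg/kg to 20 mg/kg, with a fair chance that this assay again reports only a limit.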

Compound 3, minimum effective dose: 10 mg/kg
For compound 3 the middle estimate is 2.0-fold (0.30 log units) below the measured one, within the range that was stated.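

Among the compounds shown here, no step from compound 2 to compound 3 can be read in this assay because compound 2 stands only as a limit: the limit of > 5 mg/kg in this assay, at which 1 of the 3 values shown sits.

The compounds shown leave open how far methylsulfonyl in place of bromo on an aromatic carbon moves this read-out.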